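This account rests on a few compounds, and the source may have more. Where it says the series, first, only, none or still open, it means among the compounds named here.

In a functional assay on NCI-H23 cells (Homo sapiens) for cytotoxicity, read by sulforhodamine B assay, with a stated time of 48 h, tested at 0.001 uM (on this read-out lower numbers stand for a stronger effect and higher numbers for a weaker effect at the one concentration tested), two compounds have been measured. Compound 1 `Cc1cc(O)cc(-c2nn(CC#N)cc2-c2ccnc(-c3ccc(Oc4ccccc4)cc3)c2)c1` gives 91%, and compound 2 `COc1cc(C)cc(-c2nn(CC#N)cc2-c2ccnc(-c3ccc(N(C)C)cc3)c2)c1` gives 93%. Compound 2 stands highest of the two numbers, with compound 1 the nearest, and the two lie within the scatter of each other. Compound 3 `Cc1cc(O)cc(-c2nn(CC#N)cc2-c2ccnc(-c3ccc(N(C)C)cc3)c2)c1` differs from compound 2 by hydrogen in place of methyl on an oxygen on an aromatic ring. Compound 1 carries the same hydroxy group and gives 91%, so the expected step of a number 1 percentage points lower from compound 2 to compound 3 (within the scatter) is none beyond the scatter. Compound 3 is therefore estimated at 92%, between 82% and 100%, in this assay.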

Compound 3, a percentage reported as activity, at one concentration (the size of the read-out at that concentration, not a potency): 94%
Beside the measured number, compound 3's estimate is 2 percentage points below it; low and high end bracket the measured number.
By their numbers in this assay, from the lowest: compounds 1, 2 and 3 (each within the scatter of the next).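

In this assay, the change from methoxy to hydroxy on the aromatic ring gives a number 1 percentage points higher from compound 2 to compound 3 (within the scatter), so this oxygen takes either a methyl or a hydrogen with no shift beyond the scatter. Dimethylamino in place of phenoxy on an aromatic carbon gives a number 3 percentage points higher from compound 1 to compound 3 (within the scatter), so that second place also shows no shift beyond the scatter. No evidence at hand bears on these results. Left open is whether a longer chain on this oxygen, or an amine or a carboxylic acid in place of the hydroxy, would move the read-out beyond the scatter.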